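A few compounds are considered here, and "the series" means these few. Any claim that something is new, unique, unknown or untested is made for them only; others in the source may bear on it.

In a physicochemical assay for lipophilicity (a higher number here means a more lipophilic compound, a lower number a more polar compound), compound 1 `CC(C)(C)n1ncc(OCc2nnc(-c3ccccc3Cl)o2)c(Cl)c1=O` gives 3.19, compound 2 `CC(C)(C)n1ncc(OCc2nnc(-c3cc(F)c(F)cc3F)o2)c(Cl)c1=O` gives 2.96, and compound 3 `CC(C)(C)n1ncc(OCc2nnc(-c3c(F)cccc3F)o2)c(Cl)c1=O` gives 2.75, the lowest of the three numbers; the gaps are a number 0.21 log units lower from compound 2 to compound 3 (within the scatter) and a number 0.44 log units lower from compound 1 to compound 3 (beyond the scatter). Compound 4 `CC(C)(C)n1ncc(OCc2nnc(-c3ccccc3)o2)c(Cl)c1=O` differs from compound 3 in one place: phenyl in place of 2,6-difluorophenyl on an aromatic carbon. Among the measured compounds shown here, the steps that bear on this are the two swaps of one substituted phenyl for another, a number 0.44 log units lower from compound 1 to compound 3 (beyond the scatter) and a number 0.21 log units lower from compound 2 to compound 3 (within the scatter); no measured step ends in a plain phenyl. Both of those steps were small and downward, so for compound 4 a small downward step is expected, a number 0.15 log units lower from compound 3 to compound 4 (within the scatter), likely within the scatter. Compound 4 is therefore estimated at 2.6, between 2.3 and 2.9.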

Compound 4, partition coefficient: 2.95
Compound 4: middle estimate off by 0.35 log units, on the low side; measured number above the stated range.
By their numbers in this assay, from the lowest: compounds 3, 4, 2 and 1 (each within the scatter of the next, the first and the last beyond it).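

Taking every substituent off the phenyl on this ring leaves the number within the scatter of all three substituted phenyls in this assay: a number 0.20 log units higher from compound 3 to compound 4 (within the scatter), a number 0.01 log units lower from compound 2 to compound 4 (within the scatter) and a number 0.24 log units lower from compound 1 to compound 4 (within the scatter). At this position, then, compound 4 cannot be told apart from any of the others, even though compound 1 and compound 3 do differ beyond the scatter. No evidence here accounts for this result. Still open, from the compounds shown here alone, is how the number would respond to an amine or a carboxylic acid on this phenyl.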